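Shortening the Sulfur Chain in a Cytotoxicity Test

The source may hold more compounds than are shown below. What is called first, only, known or untested is meant among the compounds shown, and "the series" means these compounds.

Of the compounds shown here, three sharing one core have been read in an ADME assay on HFF cells (Homo sapiens) for cytotoxicity, with a stated time of 8 days; on this read-out higher numbers stand for lower toxicity in this test and lower numbers for higher toxicity in this test. Compound 1 (`CNc1nc(N)nc2c1ncn2/C=C1/CC1(CO)CO`) gives 265000 nM. Compound 2 (`COCCOc1nc(N)nc2c1ncn2/C=C1/CC1(CO)CO`) is reported only as a limit, > 300000 nM. Compound 3 (`CCCCCCSc1nc(N)nc2c1ncn2/C=C1/CC1(CO)CO`) is likewise reported only as a limit, > 300000 nM, so it has no exact place on the scale. The readings thus gather at the limit of > 300000 nM in this assay, at which 2 of the 3 values shown sit.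

The change to compound 4 (`CC(C)Sc1nc(N)nc2c1ncn2/C=C1/CC1(CO)CO`) is isopropyl in place of hexyl on a sulfur, on a sulfur whose other neighbour is an aromatic carbon. Within the data shown here, no measured step alters this chain alone. The nearest are an at least 1.1-fold higher number from compound 1 to compound 3 (0.05 log units; that floor lies within the scatter), an at least 1.1-fold higher number from compound 1 to compound 2 (0.05 log units; that floor lies within the scatter) and a step that the two limits leave unreadable from compound 2 to compound 3. These steps show no fall in this assay, so no step beyond the scatter is expected here, and any rise would be hidden by the limit. The expected step is a number no higher from compound 3 to compound 4 (the limit leaves the size open). Compound 4 is estimated at 300000 nM, with an expected range from 170000 nM to 450000 nM.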

Compound 4, half-maximal cytotoxic concentration: > 300000 nM
Compound 4: only a limit was reported; the forecaster's own chance of this, stated with the estimate: 70%; the middle value lies on the limit itself.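

In this assay compound 4 is reported only as a limit, > 300000 nM. Among these compounds, the steps from compound 2 and from compound 3 to this compound join two limits and cannot be read, so the change from hexyl to isopropyl on this sulfur has no measurable size; the one readable new step is an at least 1.1-fold higher number from compound 1 to compound 4 (0.05 log units; that floor lies within the scatter). With a second chain on this sulfur, the shorter branched isopropyl, the readings now gather more tightly: the limit of > 300000 nM in this assay, at which 3 of the 4 values shown sit.

Going by these compounds, how far apart compound 2, compound 3 and compound 4 truly lie on this scale stays open. Also open, on these data alone, is whether a group of another kind on this sulfur, such as a carboxylic acid or an amine at the end of the chain, would give a number that can be read in this assay.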